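A few compounds are considered here, and "the series" means these few. Any claim that something is new, unique, unknown or untested is made for them only; others in the source may bear on it.

Values in a functional assay (aorta) with Rattus norvegicus as the target; on this read-out higher numbers stand for weaker inhibition and lower numbers for stronger inhibition:
- compound 1 `CC(C)(C)NCCCOc1ccc(S(=O)(=O)c2c(C3CC3)cn3ccccc23)cc1`: 66.5 nM
- compound 2 `CCCCN(CCCC)CCCOc1ccc(S(=O)(=O)c2c(C(C)(C)C)cn3ccccc23)cc1`: 51.9 nM
- compound 3 `CCCCN(CCCC)CCCOc1ccc(S(=O)(=O)c2c(-c3ccccc3)cn3ccccc23)cc1`: 1620 nM
- compound 4 `CCCCN(CCCC)CCCOc1ccc(S(=O)(=O)c2c(C3CC3)cn3ccccc23)cc1`: not yet measured

Compound 3 has the highest number of the three at 1620 nM, and compound 1 and compound 2 both lie well below it, beyond the scatter. The next change is cyclopropyl in place of phenyl on an aromatic carbon. Among the compounds with values here, the one measured step at this place, with phenyl in place of tert-butyl, is a 31-fold higher number from compound 2 to compound 3 (1.49 log units; beyond the scatter), which is large. Compound 1 already carries cyclopropyl there, with a different amine, and gives 66.5 nM. The step estimated in this assay is a 29-fold lower number from compound 3 to compound 4 (1.47 log units; beyond the scatter), a large one towards a lower number. For compound 4 the expected value is 55 nM, with an estimated range of 14 nM to 220 nM.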

Compound 4, half-maximal inhibitory concentration: 10.9 nM
Compound 4: the middle estimate sits 5.0-fold (0.70 log units) above what was measured; measured number below the stated range.
By their numbers in this assay, from the lowest: compound 4; then compounds 2 and 1 (each within the scatter of the next); then compound 3.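

In this assay the dibutylamino compounds put cyclopropyl lowest at this aromatic carbon, with a 150-fold lower number from compound 3 to compound 4 (2.17 log units; beyond the scatter) and a 4.8-fold lower number from compound 2 to compound 4 (0.68 log units; beyond the scatter) as the steps, so the gain holds against tert-butyl as well as phenyl. With cyclopropyl held, the amine also counts, with a 6.1-fold lower number from compound 1 to compound 4 (0.79 log units; beyond the scatter) on going to dibutylamino from (tert-butyl)amino. Nothing available here gives a reason for these differences.

Open, from the compounds shown here alone, is whether isopropyl or cyclobutyl at this carbon goes lower than cyclopropyl. Also open, going by these compounds, is how a piperidine or dipropylamino in place of dibutylamino compares with cyclopropyl held.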